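Swapping Trifluoromethyl for Fluoro on a Benzyl Arm

A few compounds are considered here, and "the series" means these few. Any claim that something is new, unique, unknown or untested is made for them only; others in the source may bear on it.

Compound 1 `Nc1ccc(/C=C2\SC(=O)N(Cc3ccc(C(F)(F)F)cc3)C2=O)cc1` carries a free aromatic amine on the shared core. Among the measured compounds shown here, in a functional assay on CCRF-CEM cells (Homo sapiens) for cytotoxicity, read by cell counting, with a stated time of 3 days (on this read-out lower numbers stand for stronger inhibition and higher numbers for weaker inhibition), compound 1 gives 32000 nM, the highest of the two numbers measured so far. For the measured compounds named here, its only measured neighbour is compound 2 `C=C(Br)C(=O)Nc1ccc(/C=C2\SC(=O)N(Cc3ccc(C(F)(F)F)cc3)C2=O)cc1`, in which that amine is acylated; in this assay compound 2 gives 8000 nM. That step is a 4.0-fold lower number from compound 1 to compound 2 (0.60 log units; beyond the scatter). Compound 3 `Nc1ccc(/C=C2\SC(=O)N(Cc3ccc(F)cc3)C2=O)cc1` differs from compound 1 at a different place altogether: fluoro in place of trifluoromethyl on an aromatic carbon. Going by the values given here, the one measured step alters the amine alone and leaves the trifluoromethyl untouched, so it offers no guide to this new change. With nothing to lean on, the step expected in this assay is no change at the digits printed from compound 1 to compound 3 (within the scatter), not beyond the scatter. Compound 3 is therefore estimated at 32000 nM, with a range from 10000 nM to 100000 nM.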

Compound 3, half-maximal inhibitory concentration: 111000 nM
Compound 3: middle estimate off by 3.5-fold (0.54 log units), on the low side, outside the stated range (above it).
By their numbers in this assay, from the lowest: compound 2; then compound 1; then compound 3.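

In this assay, the step from trifluoromethyl to fluoro on the benzyl arm is a 3.5-fold higher number from compound 1 to compound 3 (0.54 log units; beyond the scatter), so this place on the aromatic ring, para to a large group, affects the read-out even when the free amine stays the same. Compound 1 now sits between two neighbours, each changed in a different place: acylating the amine lowers the number, while this swap raises it. Nothing measured here bears on why the number rises.

Only trifluoromethyl and fluoro can be compared at this place, so a chloro group, a methoxy group or plain hydrogen there would be needed to show whether the number follows any trend across groups. Also open, going by these compounds, is whether the fluoro swap would raise the number to a similar extent with the (1-bromoethenyl)carbonyl amide of compound 2 in place of the free amine.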